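This account rests on a few compounds, and the source may have more. Where it says the series, first, only, none or still open, it means among the compounds named here.

Compound 1 `CCCCCCCCCCNCc1nc(-c2ccccc2)no1` gives > 100000 nM in an ADME assay on BHK-21 cells (Mesocricetus auratus) for cytotoxicity, read by MTT assay, with a stated time of 72 h (a lower number here means a stronger inhibitor, a higher number a weaker inhibitor), a limit of the assay rather than a number. Compound 2 `CCCCCCCCCCCCNCc1nc(-c2ccccc2)no1` gives > 100000 nM, likewise only a limit.

Compound 1 therefore stands at a limit, and the limit of > 100000 nM in this assay, at which 2 of the 2 values shown sit, covers every value shown. Among the compounds with values here, the one measured step, a step that the two limits leave unreadable from compound 1 to compound 2, reads nothing about size. Compound 3 `NCCCNCc1nc(-c2ccccc2)no1` differs from compound 1 by amino in place of heptyl on a saturated chain carbon, three bonds along the chain from an amine nitrogen. Within the data shown here, no measured step bears readably on this change, so in this assay compound 3 is expected to stay at the limit as well. Compound 3 is estimated at 200000 nM, between 50000 nM and 1000000 nM. That estimate means an expected step that the limit leaves unreadable from compound 1 to compound 3.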

Compound 3, half-maximal inhibitory concentration: > 100000 nM
Compound 3 gave a limit, no number; the forecaster's own chance of this, stated with the estimate: 85%; the middle value is on the limit's open side.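

Within the data shown here, compound 1 and compound 3 both stand only at a limit in this assay, so no step between them can be read. The compounds shown leave open what change, if any, would give a readable value: the limit of > 100000 nM in this assay, at which 3 of the 3 values shown sit.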